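This account rests on a few compounds, and the source may have more. Where it says the series, first, only, none or still open, it means among the compounds named here.

Measured so far:

compound 1, `C=C1CC[C@@H]2[C@](C)(COC(=O)c3cccs3)[C@H](O)CC[C@@]2(C)[C@@H]1C/C=C1\C=COC1=O` — in an ADME assay on HepG2 2.2.15 cells (Homo sapiens) for cytotoxicity, read by MTT assay (a higher number here means that more compound is tolerated, a lower number that less compound is tolerated), compound 1 gives 2470000 nM
compound 2, `C=C1CC[C@@H]2[C@](C)(COC(=O)c3ccccc3)[C@H](O)CC[C@@]2(C)[C@@H]1C/C=C1\C=COC1=O` — in this assay compound 2 gives 82000 nM
compound 3, `C=C1CC[C@@H]2[C@](C)(CO)[C@H](OC(=O)c3cccs3)CC[C@@]2(C)[C@@H]1C/C=C1\C=COC1=O` — in this assay compound 3 gives 257000 nM

Compound 1 and compound 2 share one core and differ only in the change (phenyl in place of thiophen-2-yl on a carbonyl carbon); this change made the step of a 30-fold lower number from compound 1 to compound 2 (1.48 log units; beyond the scatter). Compound 3 is built on a core of the same atoms joined differently, and the difference between the two cores is not broken down here. Compound 4, `C=C1CC[C@@H]2[C@](C)(CO)[C@H](OC(=O)c3ccccc3)CC[C@@]2(C)[C@@H]1C/C=C1\C=COC1=O`, has not yet been measured in this assay. Going by the values given here, it differs from compound 3 by phenyl in place of thiophen-2-yl on a carbonyl carbon, which is the same kind of change as the one from compound 1 to compound 2, made at a place described in the same words. Among the compounds with values here, the expectation for compound 4 rests on the one earlier step: the number is estimated to fall from compound 3 by a 21-fold lower number from compound 3 to compound 4 (1.33 log units; beyond the scatter), somewhat smaller than the earlier step because a 30-fold lower number from compound 1 to compound 2 (1.48 log units; beyond the scatter) was seen on a different core. Compound 4 is therefore expected to give about 12000 nM in this assay, most likely between 3000 nM and 60000 nM.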

Compound 4, half-maximal cytotoxic concentration: 103000 nM
Beside the measured number, compound 4's estimate is 8.6-fold (0.93 log units) below it; the measured number lies above the stated range.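

Putting phenyl in place of thiophen-2-yl on the carbonyl carbon gives a 2.5-fold lower number from compound 3 to compound 4 (0.40 log units; beyond the scatter) in this assay and so lowers the tolerated concentration on this core as well. The two cores share the direction of the change but not its size, so a step measured on one core gave a poor guide to how large the step would be on the other: the same change on two cores in this assay, a 30-fold lower number (1.48 log units; beyond the scatter) from compound 1 to compound 2 and a 2.5-fold lower number (0.40 log units; beyond the scatter) from compound 3 to compound 4, 12-fold (1.08 log units) apart, beyond the scatter of two such steps. These two pairs do not show which difference between the cores goes with the difference in size, nor how the same change would behave on any further core.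

The compounds shown carry only thiophen-2-yl and phenyl on this carbonyl carbon, so it remains open whether a furan-2-yl, a cyclohexyl or a simple methyl group would follow the same direction. As far as these compounds go, it also remains open how the numbers would move if an amide took the place of the ester that holds these groups.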